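The source may hold more compounds than are shown below. What is called first, only, known or untested is meant among the compounds shown, and "the series" means these compounds.

Of the compounds shown here, two have been measured in a functional assay (aorta) with Rattus norvegicus as the target; a lower number here means a stronger inhibitor, a higher number a weaker inhibitor. Compound 1, `CCO/C(O)=C1\C(COCCn2cc(C(N)=O)nn2)=NC(C)=C(C(=O)OC)C1c1cccc(Cl)c1Cl`, gives 3.16 nM in this assay. Compound 2, `CCO/C(O)=C1\C(COCCn2c(C)nc(C)c2C)=NC(C)=C(C(=O)OC)C1c1ccccc1Cl`, gives 5.01 nM in this assay; this is the higher of the two numbers, and the gap to compound 1 lies within the usual scatter, so the two values cannot be ranked. Going by the values given here, compound 1 and compound 2 differ from each other in more than one place, and no single step between them is counted here.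

Compound 3, `CCO/C(O)=C1\C(COCCn2nncc2C(N)=O)=NC(C)=C(C(=O)OC)C1c1ccccc1Cl`, has not yet been measured. It differs from compound 2 in a single place: 5-carbamoyl-1H-1,2,3-triazol-1-yl in place of 2,4,5-trimethyl-1H-imidazol-1-yl on a saturated chain carbon, two bonds along the chain from an oxygen on a saturated carbon. The shared core and the ester groups are untouched. Among the compounds with values here, no measured pair shows this particular exchange, so there is no counted step to lean on; the only guide is that both measured compounds, which carry different groups at this position, sit close together in this assay.

On that basis the step from compound 2 to compound 3 is expected to be small, a 1.0-fold lower number from compound 2 to compound 3 (0.00 log units; within the scatter), with no direction beyond the scatter. Compound 3 is therefore estimated to give about 5 nM in this assay, within a range from 2 nM to 13 nM.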

Compound 3, half-maximal inhibitory concentration: 100 nM
Estimate against measurement, compound 3: 20-fold (1.30 log units) below; measured number outside the range, above it.
By their numbers in this assay, from the lowest: compounds 1 and 2 (each within the scatter of the next); then compound 3.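

In this assay, going by these compounds alone, the exchange of 2,4,5-trimethyl-1H-imidazol-1-yl for 5-carbamoyl-1H-1,2,3-triazol-1-yl gives a 20-fold higher number from compound 2 to compound 3 (1.30 log units; beyond the scatter) and is the first step that can be read on its own. It shows that the number at this place on the saturated chain carbon depends strongly on which group is attached, even though the two groups have the same heavy-atom count and each holds one five-membered aromatic ring. Nothing shown bears on the reason for this large step.

Within the data shown here, the single step changes the ring and its substituents together, so it remains open how much of the rise belongs to the 1H-1,2,3-triazol-1-yl ring and how much to the carbamoyl group. Whether a 1H-1,2,3-triazol-1-yl group without the carbamoyl, or a simple amine at the same place, would stand nearer compound 2 or nearer compound 3 in this assay also remains to be seen.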